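The source may hold more compounds than are shown below. What is called first, only, known or untested is meant among the compounds shown, and "the series" means these compounds.

Among the compounds with values here, in an assay on HEK293 cells for inhibition of melanin-concentrating hormone receptor 1 (Homo sapiens), read by radioligand binding (on this read-out lower numbers stand for stronger inhibition and higher numbers for weaker inhibition), compound 2 `CN(C)c1nc(N[C@H]2CC[C@@H](NC(=O)c3ccc(F)cc3)CC2)nc2ccccc12` gives 9.4 nM, the lower of the two numbers so far; compound 1 `CN(C)c1nc(N[C@H]2CC[C@@H](NC(=O)c3ccc(F)c(F)c3F)CC2)nc2ccccc12` gives 38 nM, and the step from compound 1 to compound 2 was a 4.0-fold lower number from compound 1 to compound 2 (0.61 log units; beyond the scatter). Compound 3 `CN(C)c1nc(N[C@H]2CC[C@@H](NC(=O)c3cccc(Cl)c3)CC2)nc2ccccc12` carries 3-chlorophenyl in place of 4-fluorophenyl on a carbonyl carbon. Within the data shown here, only the step from compound 1 to compound 2 bears on this change, and it concerns a different halogen pattern on the same phenyl, so it gives no firm direction. For compound 3 a step in this assay of a 1.6-fold higher number from compound 2 to compound 3 (0.20 log units; within the scatter) is expected, small and likely within the scatter. Compound 3 is estimated at 15 nM, with a range of 5 nM to 50 nM.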

Compound 3, half-maximal inhibitory concentration: 4.5 nM
For compound 3 the middle estimate is 3.3-fold (0.52 log units) above the measured one; measured number below the stated range.
By their numbers in this assay, from the lowest: compound 3; then compound 2; then compound 1.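

In this assay the 3-chlorophenyl group gives a 2.1-fold lower number from compound 2 to compound 3 (0.32 log units; beyond the scatter), so a change of halogen and its place on this phenyl, with the heavy-atom count unchanged, moves the number beyond the scatter. The wider step, an 8.4-fold lower number from compound 1 to compound 3 (0.93 log units; beyond the scatter), shows that this single position on the carbonyl carbon spans a clear range among the three compounds. Nothing measured here accounts for either step.

The compounds shown do not separate the halogen from its place, which 3-fluorophenyl and 4-chlorophenyl would do. On these data alone, whether a non-halogen group such as methoxy or an amine on the phenyl fits here also remains open.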